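Compound 1 to Compound 4: One Benzyl Exchange

This account rests on a few compounds, and the source may have more. Where it says the series, first, only, none or still open, it means among the compounds named here.

Within the data shown here, compound 1 `O=c1c2cnn(-c3ccc(F)cc3)c2ncn1CC1(O)CCN(Cc2ccccc2F)CC1` is the only member of this set with a number in an assay on Sf21 cells for inhibition of ubiquitin carboxyl-terminal hydrolase 7 (Homo sapiens), read by spectrophotometry, with stated times of 30 min and 2 h (on this read-out lower numbers stand for stronger inhibition and higher numbers for weaker inhibition), where compound 1 gives 9800 nM. Compound 2 `O=c1c2cnn(-c3ccc(F)cc3)c2ncn1CC1(O)CCN(Cc2ccc(C(F)(F)F)cc2)CC1` belongs to the same series but carries only "not determined" (no result reported) in this assay, and compound 3 `COC(=O)c1cccc(CN2CCC(O)(Cn3cnc4c(cnn4-c4ccc(F)cc4)c3=O)CC2)c1` likewise carries only "not determined" (no result reported) in this assay, so compound 1 stands alone as the point of reference. Compound 4 `N#Cc1cc(Cl)ccc1CN1CCC(O)(Cn2cnc3c(cnn3-c3ccc(F)cc3)c2=O)CC1` differs from compound 1 in one place: 4-chloro-2-cyanophenyl in place of 2-fluorophenyl on a saturated chain carbon bound to an amine nitrogen in a ring. Among the measured compounds shown here, no pair of measured compounds shows how a change of this kind plays out in this assay, so the size of the step cannot be read from the data and any forecast rests on the single value of compound 1. Compound 4 is expected to give 5000 nM, within 1500 nM to 16000 nM. The expected step of a 2.0-fold lower number from compound 1 to compound 4 (0.29 log units; within the scatter) is a modest gain that may well stay inside the usual scatter.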

Compound 4, half-maximal inhibitory concentration: 11400 nM
For compound 4 the middle estimate is 2.3-fold (0.36 log units) below the measured one; measured number inside the range.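

In this assay, exchanging 2-fluorobenzyl for 4-chloro-2-cyanobenzyl gives a 1.2-fold higher number from compound 1 to compound 4 (0.07 log units; within the scatter), so the two compounds cannot be told apart, and this place on the ring amine accepts the larger group, with its nitrile and chlorine, with no difference beyond the scatter. No measurement at hand accounts for this result.

Compound 2 and compound 3 have no numbers, so steps to them cannot be read. From the compounds shown here alone, whether a carboxylic acid or an amine on the benzyl ring, or a longer chain in place of the benzyl, would move the number in this assay remains open.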